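Sulfonyl aryl swap: from fluorophenyl to methylphenyl

The source may report more compounds than this note shows. Statements on the series, on what has been measured and on what is new or still open speak of the compounds shown alone.

Measured compounds:
compound 1, `O=C(NCc1ccc(CNS(=O)(=O)c2cccc(C(F)(F)F)c2)cc1)c1ccc(F)cc1`, 100 nM
compound 2, `O=C(NCc1ccc(CNS(=O)(=O)c2ccccc2Cl)cc1)c1ccc(F)cc1`, 1000 nM
compound 3, `O=C(NCc1ccc(CNS(=O)(=O)c2ccc(F)cc2)cc1)c1ccc(F)cc1`, 1 nM

In an assay on MDA-MB-231 cells for binding affinity to C-X-C chemokine receptor type 4 (Homo sapiens), read by fluorescence and microscopy, with stated times of 10 min and 30 min (on this read-out higher numbers stand for an effect only at larger amounts of compound and lower numbers for an effect already at smaller amounts), compound 3 gives the lowest number of the three; compound 1 is nearest, with a 100-fold lower number from compound 1 to compound 3 (2.00 log units; beyond the scatter) separating them, and compound 2 is furthest, with a 1000-fold lower number from compound 2 to compound 3 (3.00 log units; beyond the scatter). Compound 4, `Cc1cccc(S(=O)(=O)NCc2ccc(CNC(=O)c3ccc(F)cc3)cc2)c1`, has not yet been measured. The change from compound 3 is 3-methylphenyl in place of 4-fluorophenyl on a sulfonyl sulfur. Going by the values given here, both earlier steps onto the 4-fluorophenyl group gave large gains, and the only other group tried at this place carrying a group on the ring away from the attachment, in compound 1, sits well above compound 3. A higher number is therefore expected for compound 4, estimated at 50 nM, in the range 5 nM to 500 nM, a step of a 50-fold higher number from compound 3 to compound 4 (1.70 log units; beyond the scatter).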

Compound 4, effective concentration (reported as EC, without a stated level of effect): 1 nM
The estimate for compound 4 lay 50-fold (1.70 log units) above the measured number, and the stated range ends above it.
By their numbers in this assay, from the lowest: compounds 3 and 4 (each within the scatter of the next); then compound 1; then compound 2.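

The 3-methylphenyl group serves as well as 4-fluorophenyl on the sulfonyl sulfur, with no change at the digits printed from compound 3 to compound 4 (within the scatter), so a high number does not follow from simply moving away from 4-fluorophenyl. The group on the ring matters: methyl in place of trifluoromethyl gives a 100-fold lower number from compound 1 to compound 4 (2.00 log units; beyond the scatter), and 3-methylphenyl in place of 2-chlorophenyl gives a 1000-fold lower number from compound 2 to compound 4 (3.00 log units; beyond the scatter). No evidence here explains these differences. Going by these compounds, what an amine or a carboxylic acid on this ring would do remains open.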